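Pyridin-2-yl Replacing Hydroxy on an Amide-Type Nitrogen

A few compounds are considered here, and "the series" means these few. Any claim that something is new, unique, unknown or untested is made for them only; others in the source may bear on it.

Measured in a functional assay on HO8910 cells (Homo sapiens) for inhibition, read by MTT assay, with a stated time of 24 h, tested at 10 ug/mL (on this read-out higher numbers stand for more inhibition of growth at the one concentration tested and lower numbers for less inhibition of growth), so far:

Compound 1 `CC(=O)SCCC(CCCCC(=O)O)SC(C)=O` gives 1.61%
Compound 2 `O=C(CCCCC1CCSS1)NO` gives "not active" (no number reported)
Compound 3 `O=C(CCCCC(S)CCS)NO` gives 26.2%

Compound 2 has no single number to its name and was reported only as "not active" (no number reported) in this series. It therefore offers a verdict rather than a position on the scale. Compound 3 (26.2%) is the only one of the three to show a figure clear of the scatter around compound 1 (1.61%).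

The next compound to be tested is compound 4 `O=C(CCCCC1CCSS1)Nc1ccccn1` and it has no reading yet. The change pyridin-2-yl in place of hydroxy on an amide-type nitrogen puts pyridin-2-yl in place of hydroxy on an amide-type nitrogen and leaves the rest of the structure as it was. Within the data shown here, no pair of measured compounds shows what such an exchange does, so the only anchor is the reading of compound 2 ("not active" (no number reported)). In this assay no step beyond the scatter is expected, and any small shift could only point upward from that reading. Compound 4 is estimated at 6% with an expected range of 0% to 22% on this reasoning, and a report of no activity would be no surprise.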

Compound 4, percent growth inhibition at one concentration: "not active" (no number reported)
The entry for compound 4 holds no number, and the estimate cannot be compared.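

In this assay compound 2 gives "not active" (no number reported) and compound 4 gives "not active" (no number reported), so no step can be read between them. The compounds shown leave open whether pyridin-2-yl in place of hydroxy on an amide-type nitrogen changes growth inhibition at all. No evidence at hand bears on this result.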